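The compounds below may be only part of what the source reports. "The series", "measured", "known", "first", "only" and "open" are said of these compounds alone.

Measured compounds in this series:

- compound 1 `Cc1cc(NC(=O)Cn2nnc(-c3ccccc3)n2)n(C2CC2)n1`: in an assay on HEK293 cells for activation of Kir3.1/Kir3.2 (Homo sapiens), read by thallium flux (on this read-out lower numbers stand for smaller maximal responses and higher numbers for larger maximal responses), compound 1 gives > 78%, which is a limit of the assay and not a number.
- compound 2 `Cc1cc(NC(=O)Cn2nnc(-c3ccccc3)n2)n(C2CCS(=O)(=O)CC2)n1`: in this assay compound 2 gives > 25%, again only a limit.

Compound 2 therefore stands on a limit alone (the limit of > 25% in this assay, at which 1 of the 2 values shown sits), with no number of its own in this assay. Among the compounds with values here, the one measured step at the same position, a step that the two limits leave unreadable from compound 1 to compound 2, stays unreadable, since both ends sit on limits the limit of > 25% in this assay, at which 1 of the 2 values shown sits (the limit of > 78% in this assay, at which 1 of the 2 values shown sits).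

Compound 3 `Cc1cc(NC(=O)Cn2nnc(-c3ccccc3)n2)n(Cc2ccccc2)n1` differs from compound 2 in one place: benzyl in place of 1,1-dioxothian-4-yl on an aromatic nitrogen. Within the data shown here, no measured step covers this exchange, and the neighbouring step gives no size, so no direction beyond the scatter can be expected in this assay. The step expected is a step that the limit leaves unreadable from compound 2 to compound 3. Compound 3 is estimated at 55% in this assay, within 25% to 90%, with a fair chance that only a limit is reported.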

Compound 3, largest response reached (Emax), in percent of the reference or control that the assay uses: 74%
The estimate for compound 3 lay 19 percentage points below the measured number, and the stated range covers the measured number.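

Compound 3 gives the series its first number rather than a limit in this assay: compound 3 reaches 74%, so benzyl on this aromatic nitrogen, with its six-membered aromatic ring of carbon only, keeps a readable maximal response. Against cyclopropyl, the only readable result is a number at least 4 percentage points lower from compound 1 to compound 3 (that floor lies within the scatter), a floor that does not separate the two groups. The exchange of 1,1-dioxothian-4-yl for benzyl cannot be read, because compound 2 rests on a limit and not a number: the limit of > 25% in this assay, at which 1 of the 3 values shown sits.

As far as these compounds go, how far the true maximal response of compound 1 lies from that of compound 3 stays open. Also open, from the compounds shown here alone, is how a longer chain such as 2-phenylethyl, or a piperidin-4-yl with its ring amine, would read on the same aromatic nitrogen in this assay.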